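This account rests on a few compounds, and the source may have more. Where it says the series, first, only, none or still open, it means among the compounds named here.

Measured so far in an ADME assay on HeLa cells (Homo sapiens) for cytotoxicity; a lower number here means that less compound is tolerated, a higher number that more compound is tolerated:
- compound 1 (`CCN(CC)CN1C(=O)/C(=N/NC(=S)Nc2ccccc2)c2cc(Cl)ccc21`) gives 13500 nM as its half-maximal cytotoxic concentration
- compound 2 (`CCN(CC)CN1C(=O)/C(=N/NC(=S)Nc2ccccc2)c2ccccc21`) gives 10800 nM as its half-maximal cytotoxic concentration

Among the measured compounds shown here, compound 1 stands level with compound 2, the only other compound measured, and the two values cannot be told apart: the gap is a 1.3-fold lower number from compound 1 to compound 2 (0.10 log units; within the scatter) and no more.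

Compound 3 (`CCN(CC)CN1C(=O)/C(=N/NC(=S)Nc2ccc(C)cc2)c2cc(Cl)ccc21`) has not yet been measured. It differs from compound 1 by methyl in place of hydrogen on an aromatic carbon, which in words is methyl in place of hydrogen on an aromatic carbon, turning phenyl to 4-methylphenyl.

For the measured compounds named here, no measured step covers this exact change, so the evidence is indirect. Going by the values given here, the only step available is a 1.3-fold lower number from compound 1 to compound 2 (0.10 log units; within the scatter), and it exchanges chloro for hydrogen, not hydrogen for methyl. Among the compounds with values here, as the one structural change measured in this assay stayed within the scatter, no step beyond the scatter is expected here, and no direction can be favoured.

The estimated step is a 1.1-fold lower number from compound 1 to compound 3 (0.05 log units; within the scatter), which would leave the two compounds level. For compound 3 the expected value is 12000 nM, with an estimated range from 5500 nM to 26000 nM.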

Compound 3, half-maximal cytotoxic concentration: > 100000 nM
Compound 3 ended at the assay's limit (the forecaster's own chance of this, stated with the estimate: 5%); middle value at least 8.3-fold (0.92 log units) from the limit.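

In this assay, among the compounds shown here, the change of phenyl to 4-methylphenyl is the first structural change to move the half-maximal cytotoxic concentration beyond the scatter, giving an at least 7.4-fold higher number from compound 1 to compound 3 (0.86 log units; beyond the scatter). For the compounds shown here, the only earlier change, hydrogen in place of chloro on an aromatic carbon elsewhere in the molecule, gave a 1.3-fold lower number from compound 1 to compound 2 (0.10 log units; within the scatter), so this series now holds one place where a change of a single heavy atom shifts the read-out and one where the change measured did not. Compound 3 gives > 100000 nM, which is a limit of the assay and not a number, so the step has a lower bound but no known full size: the limit of > 100000 nM in this assay, at which 1 of the 3 values shown sits.

On these data alone, it remains open whether the shift belongs to methyl itself or would also follow from another group at this place on the ring, such as chloro, methoxy, a longer chain such as ethyl, an amine or a carboxylic acid. As far as these compounds go, it also remains open whether methyl at this place would give a step of similar size on the core of compound 2, which carries hydrogen in place of chloro, and the data give no cause for the shift.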